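The compounds below may be only part of what the source reports. "The series", "measured", "known", "first", "only" and "open" are said of these compounds alone.

Values in a functional assay on RAW264.7 cells (Mus musculus) for inhibition, read by Griess assay, with stated times of 1 h and 24 h; a higher number here means a weaker inhibitor, a lower number a stronger inhibitor:
Compound 1 `COCCOc1ccc(C(O)C2OC(=O)c3c(OC)cc(OC)cc32)cc1`: > 10000 nM, a limit of the assay
Compound 2 `COc1cc(OC)c2c(c1)C(C(O)c1ccc(OCc3ccc(F)cc3)cc1)OC2=O`: 760 nM
Compound 3 `COc1cc(OC)c2c(c1)C(C(O)c1ccc(OCc3ccc(Cl)cc3)cc1)OC2=O`: 4320 nM

Of the two values that are true numbers, compound 3 has the higher, which makes it the weaker inhibitor of that pair. Compound 4 `COc1cc(OC)c2c(c1)C(C(O)c1ccc(OCc3ccc(Br)cc3)cc1)OC2=O` has bromo in place of chloro on an aromatic carbon, para to a large group (bromo in place of chloro on an aromatic carbon). Going by the values given here, only one measured step swaps one halogen for another: a 5.7-fold higher number from compound 2 to compound 3 (0.75 log units; beyond the scatter). It went to a higher number, so a small further rise in this assay is expected, perhaps no larger than the scatter. The expected change is a 1.2-fold higher number from compound 3 to compound 4 (0.06 log units; within the scatter). For compound 4 the estimated value is 5000 nM, with an expected range from 1800 nM to 10000 nM.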

Compound 4, half-maximal inhibitory concentration: 6530 nM
The estimate for compound 4 lay 1.3-fold (0.12 log units) below the measured number; the range from low to high includes it.
By their numbers in this assay, from the lowest: compound 2; then compounds 3 and 4 (each within the scatter of the next). At a limit, above all of these: compound 1.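

In this assay, bromo in place of chloro on an aromatic carbon gives a 1.5-fold higher number from compound 3 to compound 4 (0.18 log units; within the scatter), so compound 3 and compound 4 cannot be told apart. Fluoro stands apart from bromo as well as from chloro, with an 8.6-fold higher number from compound 2 to compound 4 (0.93 log units; beyond the scatter). Compound 1 stands at a limit of the assay: the limit of > 10000 nM in this assay, at which 1 of the 4 values shown sits 4-Bromophenyl in place of methoxymethyl gives an at least 1.5-fold lower number from compound 1 to compound 4 (0.18 log units; that floor lies within the scatter), and this step is only a floor.

On these data alone, it remains open how a methoxy group, a nitrile or an amine at this position would compare with fluoro. As far as these compounds go, it is also open whether a bare hydrogen there would read closer to fluoro or to chloro and bromo.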